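The source may hold more compounds than are shown below. What is called first, only, known or untested is meant among the compounds shown, and "the series" means these compounds.

Compound 1 `CC(C)=CCC1Cc2c(OCCCNS(=O)(=O)c3ccc(C(F)(F)F)cc3)cc(=O)n(CCCO)c2CC1(C)C`, tested in a functional assay on PANC-1 cells (Homo sapiens) for inhibition, read by MTT assay, with a stated time of 24 h, tested at 10 uM (a higher number here means more inhibition at the concentration tested (going by the name of the read-out), a lower number less inhibition), gives 29.6%. Its two measured companions differ from it only in the group on the aromatic carbon: compound 2 `CC(C)=CCC1Cc2c(OCCCNS(=O)(=O)c3ccc(Cl)cc3)cc(=O)n(CCCO)c2CC1(C)C` gives 24.7%, and compound 3 `CC(C)=CCC1Cc2c(OCCCNS(=O)(=O)c3ccc(Br)cc3)cc(=O)n(CCCO)c2CC1(C)C` gives 19.5%. The steps read a number 4.9 percentage points lower from compound 1 to compound 2 (within the scatter), a number 10.1 percentage points lower from compound 1 to compound 3 (beyond the scatter) and a number 5.2 percentage points lower from compound 2 to compound 3 (within the scatter). Compound 1 thus stands highest of the three numbers, though only its gap to compound 3 lies beyond the scatter.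

Compound 4 `CC(C)=CCC/C(C)=C/CC1Cc2c(OCCCNS(=O)(=O)c3ccc(C(F)(F)F)cc3)cc(=O)n(CCCO)c2CC1(C)C` has not yet been measured. It differs from compound 1 by 3-methylbut-2-en-1-yl in place of hydrogen on a saturated chain carbon bound to a double-bonded chain carbon. None of the three measured steps touches this part of the molecule; each of them exchanges one group on the aromatic carbon and leaves the chain as it is, so none bears directly on the change to compound 4. Going by the values given here, with no measured step pointing either way, the expected step is a number 0.4 percentage points higher from compound 1 to compound 4 (within the scatter), that is, none beyond the scatter. Compound 4 is therefore estimated at 30%, with an expected range from 18% to 42%.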

Compound 4, a percentage reported as inhibition, at one concentration (the size of the read-out at that concentration, not a potency): 26.4%
Compound 4: the middle estimate sits 3.6 percentage points above what was measured; the measured number falls inside the stated range.
By their numbers in this assay, from the lowest: compounds 3, 2, 4 and 1 (each within the scatter of the next, the first and the last beyond it).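

In this assay, going by these compounds alone, the earlier compounds changed only the group on the aromatic carbon, so this is the first reading of a change in the chain: adding 3-methylbut-2-en-1-yl on the saturated chain carbon bound to a double-bonded chain carbon, which turns the 3-methylbut-2-en-1-yl chain into 3,7-dimethylocta-2,6-dien-1-yl, gives a number 3.2 percentage points lower from compound 1 to compound 4 (within the scatter). At this one concentration, then, a chain extended by 5 heavy atoms leaves the read-out within the scatter of the shorter one, with the trifluoromethyl group held in place. No measurement shown here accounts for this result.

Going by these compounds, it remains open whether the chloro and bromo compounds would answer the same extension in the same way. Also open, on these data alone, is how an amine or a carboxylic acid in place of the 3-methylbut-2-en-1-yl would read at this position.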